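Estimating partition for a sulfamide replacing methylpiperazine

The source may hold more compounds than are shown below. What is called first, only, known or untested is meant among the compounds shown, and "the series" means these compounds.

Compound 1 `CN1CCN(C[C@H]2CN(c3ccc(-n4cc(-c5ccccn5)cn4)c(F)c3)C(=O)O2)CC1` sits in the middle of three measured compounds. In a physicochemical assay for lipophilicity, read by HPLC, measured as octanol-water partition (a higher number here means a more lipophilic compound, a lower number a more polar compound), compound 1 gives 2.2. Compound 2 `O=C1O[C@@H](CN2CCCCC2)CN1c1ccc(-n2cc(-c3ccccn3)cn2)c(F)c1` gives 3.1, and compound 3 `O=C1O[C@@H](Cn2ccnc2)CN1c1ccc(-n2cc(-c3ccccn3)cn2)c(F)c1` gives 1.73. The step of a number 0.90 log units higher from compound 1 to compound 2 (beyond the scatter) comes from a piperidin-1-yl replacing the 4-methylpiperazin-1-yl; the step of a number 0.47 log units lower from compound 1 to compound 3 (beyond the scatter) comes from a 1H-imidazol-1-yl taking the same place; between them lies a number 1.37 log units lower from compound 2 to compound 3 (beyond the scatter).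

Compound 4 `CN(C)S(=O)(=O)NC[C@H]1CN(c2ccc(-n3cc(-c4ccccn4)cn3)c(F)c2)C(=O)O1` differs from compound 1 by (dimethylsulfamoyl)amino in place of 4-methylpiperazin-1-yl on a saturated chain carbon bound to a saturated ring carbon. Within the data shown here, no measured step swaps the ring for a chain group of this kind, so the guide is loose. The step from compound 1 to compound 3 shows that replacing the 4-methylpiperazin-1-yl with a group carrying hydrogen-bond acceptors in a ring moved the number modestly downward; the new group carries one hydrogen-bond donor and two acceptors on a chain, and a step of similar modest size downward is expected, a number 0.30 log units lower from compound 1 to compound 4 (within the scatter). For compound 4 the expected value is 1.9, likely between 1.3 and 2.5.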

Compound 4, partition coefficient: 1.38
Estimate against measurement, compound 4: 0.52 log units above; low and high end bracket the measured number.
By their numbers in this assay, from the lowest: compound 4; then compound 3; then compound 1; then compound 2.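

In this assay the open-chain (dimethylsulfamoyl)amino group gives the lowest number of the set at this place, on a saturated chain carbon bound to a saturated ring carbon, with a number 0.82 log units lower from compound 1 to compound 4 (beyond the scatter) and a number 1.72 log units lower from compound 2 to compound 4 (beyond the scatter). It also goes further than the one polar ring group shown, with a number 0.35 log units lower from compound 3 to compound 4 (beyond the scatter), so a group without a ring can take this number lower than any of the three ring groups. Nothing available here accounts for the size of these steps.

As far as these compounds go, what stays open is whether the low number goes with the sulfonyl unit, the amide hydrogen or simply the open chain. An acetamide or a plain dimethylamino group on the same carbon would help to separate these possibilities.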